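The source may report more compounds than this note shows. Statements on the series, on what has been measured and on what is new or still open speak of the compounds shown alone.

Compound 1 `CC(Oc1ccccc1-c1ccccc1)C1=NCCO1`: 10000 nM
Compound 2 `CC(Oc1ccccc1-c1ccccc1O)C1=NCCN1`: 1000 nM
Compound 3 `CC(Oc1ccccc1-c1ccc([N+](=O)[O-])cc1)C1=NCCN1`: 501 nM

Of the compounds shown here, three have been measured in an assay on CHO cells for displacement of a labelled ligand from Alpha-2B adrenergic receptor (Homo sapiens); a higher number here means a weaker inhibitor, a lower number a stronger inhibitor. Compound 1 stands at the highest of the three numbers, and both of its neighbours lie beyond the scatter: compound 2 gives a lower number, and compound 3, the furthest, a lower number still. Among the measured compounds shown here, compounds 2 and 3 carry a different five-membered ring from compound 1, so no single-change step among the measured compounds is available.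

Compound 4 `CC(Oc1ccccc1-c1ccccc1)C1=NCCC1` differs from compound 1 in one place: a group of 5 heavy atoms (4 carbon, 1 nitrogen; one five-membered non-aromatic ring with 1 hetero atom) in place of a group of 5 heavy atoms (3 carbon, 1 nitrogen, 1 oxygen; one five-membered non-aromatic ring with 2 hetero atoms), on a saturated chain carbon bound to an oxygen on an aromatic ring and a saturated chain carbon. For the measured compounds named here, no measured pair shows what such a change does here, so the expectation rests on compound 1 alone, whose value in this assay is 10000 nM. A step of a 1.3-fold lower number from compound 1 to compound 4 (0.10 log units; within the scatter) is expected, that is, none beyond the scatter. Compound 4 is therefore estimated at 8000 nM, with a range from 2500 nM to 25000 nM.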

Compound 4, inhibition constant: 10000 nM
Beside the measured number, compound 4's estimate is 1.3-fold (0.10 log units) below it; measured number inside the range.
By their numbers in this assay, from the lowest: compounds 3 and 2 (each within the scatter of the next); then compounds 1 and 4 (each within the scatter of the next).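

In this assay, replacing the five-membered non-aromatic ring with 2 hetero atoms by the one with 1 hetero atom gives no change at the digits printed from compound 1 to compound 4 (within the scatter). Among the compounds shown here, this is the first single-change step in the set, and it shows that, on this saturated chain carbon, going from 2 hydrogen-bond acceptors to 1 in the ring leaves the reading within the scatter. No measurement at hand explains this result.

Going by these compounds, it remains open whether the same holds for other groups at this place, such as an open-chain amine or a carboxylic acid. For the compounds shown here, no single-change pair connects the ring of compound 1 to that of compound 2 or compound 3, so the effect of that ring change cannot be read from these compounds.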